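Nitro for chloro on a weakly active pair

This account rests on a few compounds, and the source may have more. Where it says the series, first, only, none or still open, it means among the compounds named here.

- Compound 1 `O=C(Nc1nc2ccccc2[nH]1)c1cc2ccccc2oc1=O` with 1200000 nM
- Compound 2 `O=C(Nc1nc2ccccc2[nH]1)c1cc2cc(Cl)ccc2oc1=O` with 4000000 nM

In a functional assay on the whole organism (strain Wistar) for inhibition, with Rattus norvegicus as the target, read by paw edema, in the formalin test, with a stated time of 6 h (a lower number here means that less compound is needed, a higher number that more compound is needed for the effect), compound 2 stands highest of the two measured compounds. Compound 3 `O=C(Nc1nc2ccccc2[nH]1)c1cc2cc([N+](=O)[O-])ccc2oc1=O` carries nitro in place of chloro on an aromatic carbon. Within the data shown here, the only measured step bearing on this is a 3.3-fold higher number from compound 1 to compound 2 (0.52 log units; beyond the scatter), a modest one beyond the scatter, for chloro in place of hydrogen. Among the measured compounds shown here, no measured step replaces chloro itself, so the direction stays open and no step beyond the scatter is expected in this assay. The expected step is a 1.3-fold lower number from compound 2 to compound 3 (0.12 log units; within the scatter). The estimated value of compound 3 is 3000000 nM, with an expected range from 1000000 nM to 9000000 nM.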

Compound 3, half-maximal effective concentration: 5000000 nM
For compound 3 the middle estimate is 1.7-fold (0.22 log units) below the measured one; measured number inside the range.
By their numbers in this assay, from the lowest: compound 1; then compounds 2 and 3 (each within the scatter of the next).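

In this assay, the step of a 1.3-fold higher number from compound 2 to compound 3 (0.10 log units; within the scatter) lies within the scatter, so nitro and chloro cannot be told apart at this position on the aromatic carbon. The step of a 4.2-fold higher number from compound 1 to compound 3 (0.62 log units; beyond the scatter) is modest but beyond the scatter, so both groups in place of hydrogen give a higher number than compound 1 has, and the earlier single step with chloro now has a second example. Nothing available gives a reason for these steps. Going by these compounds, whether an amine or a carboxylic acid here would also give a number above that of compound 1 stays open, as does whether any group at this position could give a lower number than hydrogen.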